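Replacing the terminal hydroxy of compound 3 with ethyl

This account rests on a few compounds, and the source may have more. Where it says the series, first, only, none or still open, it means among the compounds named here.

Measured so far:
compound 1 `CCCCCCCCCCCC(=O)C(C)(C)C(=O)N(C)c1c(OC)cc(OC)cc1OC`: > 1000 nM
compound 2 `CC(C)c1cccc(C(C)C)c1NC(=O)CC(=O)CCCCCCCCCCOC1CCCCO1`: 57 nM
compound 3 `CC(C)c1cccc(C(C)C)c1NC(=O)CC(=O)CCCCCCCCCCO`: 230 nM

In a functional assay on microsomes from intestine for inhibition of acyl-CoA:cholesterol acyltransferase (Oryctolagus cuniculus) (on this read-out lower numbers stand for stronger inhibition and higher numbers for weaker inhibition), compound 1 gives a value that is a limit of the assay, not a number. Compound 3 has the highest number of the two numbers shown; its nearest neighbour is compound 2, and a 4.0-fold higher number from compound 2 to compound 3 (0.61 log units; beyond the scatter) separates them. Compound 4 `CCCCCCCCCCCCC(=O)CC(=O)Nc1c(C(C)C)cccc1C(C)C` differs from compound 3 by ethyl in place of hydroxy on a saturated chain carbon, ten or more bonds along the chain from a carbonyl carbon. Going by the values given here, the only measured step that bears on this change is a 4.0-fold higher number from compound 2 to compound 3 (0.61 log units; beyond the scatter), where the bare hydroxy end gave the higher number. Putting a carbon group in place of that hydroxy is expected to move the number the other way, a step of about a 3.3-fold lower number from compound 3 to compound 4 (0.52 log units; beyond the scatter). Compound 4 is therefore estimated at 70 nM, within 25 nM to 200 nM.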

Compound 4, half-maximal inhibitory concentration: 11 nM
For compound 4 the middle estimate is 6.4-fold (0.80 log units) above the measured one; the whole stated range lies above it.
By their numbers in this assay, from the lowest: compound 4; then compound 2; then compound 3. At a limit, above all of these: compound 1.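

In this assay ethyl in place of hydroxy gives a 21-fold lower number from compound 3 to compound 4 (1.32 log units; beyond the scatter) and ethyl in place of (oxan-2-yl)oxy gives a 5.2-fold lower number from compound 2 to compound 4 (0.71 log units; beyond the scatter) as well. The chain end without oxygen therefore gives the lowest number of these three compounds, so this far-out place on the chain matters more than the earlier step showed. Nothing measured here explains why. Going by these compounds, whether a longer chain, a shorter chain, an amine or a carboxylic acid at this chain end would lower the number further remains open.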